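The source may hold more compounds than are shown below. What is called first, only, known or untested is meant among the compounds shown, and "the series" means these compounds.

In an assay on HL-60 cells for inhibition of glutathione S-transferase P (Homo sapiens), read by spectrophotometry, tested at 20 uM (a lower number here means less inhibition, a higher number more inhibition at the concentration tested (going by the name of the read-out)), compound 1 `Cc1cc(C)cc(/C=C2\CN(CC(=O)O)c3c(C)cccc3C2=O)c1` gives 17.5%. Compound 2 `Cc1cccc2c1N(CC(=O)O)C/C(=C\c1ccc(N(C)C)cc1)C2=O` gives 13.2% in this assay, a value that lies within the scatter of compound 1. Compound 3 `Cc1cccc2c1N(CC(=O)O)C/C(=C\c1ccccc1)C2=O` differs from compound 2 in one place: hydrogen in place of dimethylamino on an aromatic carbon. Among the compounds with values here, no measured pair of compounds shows the effect of this change, so nothing beyond the scatter is expected in either direction, and the estimated step comes out as a number 1.8 percentage points higher from compound 2 to compound 3 (within the scatter). For compound 3 the expected value in this assay is 15%, within a range from 5% to 28%.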

Compound 3, a percentage reported as inhibition, at one concentration (the size of the read-out at that concentration, not a potency): 27.9%
Estimate against measurement, compound 3: 12.9 percentage points below, and the stated range covers the measured number.
By their numbers in this assay, from the lowest: compounds 2 and 1 (each within the scatter of the next); then compound 3.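

In this assay the aromatic ring carrying no substituent now separates from both substituted rings: hydrogen in place of dimethylamino gives a number 14.7 percentage points higher from compound 2 to compound 3 (beyond the scatter) on this carbon, and phenyl in place of 3,5-dimethylphenyl gives a number 10.4 percentage points higher from compound 1 to compound 3 (beyond the scatter) in the second comparison. Thus two different substituents on this ring both stand lower than hydrogen among these three compounds. No evidence shown bears on the reason for this. From the compounds shown here alone, whether a single fluorine or methoxy at this place would keep the number of compound 3 remains open, as does the role of the carboxylic acid.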